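The compounds below may be only part of what the source reports. "The series", "measured", "known", "first", "only" and "open" are said of these compounds alone.

Measured so far:
compound 1, `COc1cc(-n2cnc3ccc(-c4ccccc4Cl)cc32)cc(OC)c1OC` — > 10000 nM
compound 2, `COc1cc(-n2cnc3ccc(-c4ccc([N+](=O)[O-])cc4)cc32)cc(OC)c1OC` — 740 nM

In a functional assay on MCF7 cells (Homo sapiens) for antiproliferative activity, read by MTT assay, with a stated time of 72 h (on this read-out lower numbers stand for stronger inhibition and higher numbers for weaker inhibition), compound 1 gives > 10000 nM, which is a limit of the assay and not a number. Compound 2 gives 740 nM in this assay, the only number shown. The other value, that of compound 1, is a limit (the limit of > 10000 nM in this assay, at which 1 of the 2 values shown sits). Among the compounds with values here, the single measured step is an at least 13-fold lower number from compound 1 to compound 2 (1.13 log units; beyond the scatter), and it concerns a different pair of aryl groups than the one now in question.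

Compound 3, `COc1cc(-n2cnc3ccc(-c4cccc(O)c4)cc32)cc(OC)c1OC`, is not yet measured. Relative to compound 2 the change is 3-hydroxyphenyl in place of 4-nitrophenyl on an aromatic carbon. Within the data shown here, no measured step covers this change directly; the step from compound 1 to compound 2 shows only that the aryl group on the shared core moves the read-out strongly. The number for compound 3 is expected to be a weaker result than for compound 2, a step of about a 2.7-fold higher number from compound 2 to compound 3 (0.43 log units; beyond the scatter). The estimate for compound 3 is 2000 nM, with a range from 300 nM to 15000 nM.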

Compound 3, half-maximal inhibitory concentration: 350 nM
Estimate against measurement, compound 3: 5.7-fold (0.76 log units) above; low and high end bracket the measured number.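

In this assay the change at this position gives a 2.1-fold lower number from compound 2 to compound 3 (0.33 log units; beyond the scatter), so the 4-nitrophenyl group is not required for a measured number on the shared core, and a group with a hydrogen-bond donor is accepted there. Against 2-chlorophenyl, the 3-hydroxyphenyl group gives an at least 28-fold lower number from compound 1 to compound 3 (1.45 log units; beyond the scatter). Compound 1 stands at a limit and not a number, so that step has no fixed size: the limit of > 10000 nM in this assay, at which 1 of the 3 values shown sits.

The three aryl groups differ in both substituent and substituent place, so the compounds shown do not separate the contribution of the hydroxyl from that of its place on the ring. On these data alone, how a 4-hydroxyphenyl group, a methoxy group in place of the hydroxyl, or an amine or carboxylic acid on that ring would read in this assay remains open.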